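Lengthening the amide chain by one carbon

The source may hold more compounds than are shown below. What is called first, only, known or untested is meant among the compounds shown, and "the series" means these compounds.

Compound 1: `CCCNC(=O)CC1CCc2cc(OC)c(OC)cc21` — 26.6%
Compound 2: `CCCCNC(=O)CC1CCc2cc(OC)c(OC)cc21` — 25%

Of the compounds shown here, two built on a shared core have been tested in a functional assay on the whole organism (strain Wistar) for inhibition, with Rattus norvegicus as the target, read by paw edema, with stated times of 60 min and 4 h, at a dose of 100 mg/kg by the oral route; a lower number here means less inhibition, a higher number more inhibition at the dose given (going by the name of the read-out). Compound 1 gives 26.6% in this assay, while compound 2 gives 25%. Going by the values given here, the single step between them, a number 1.6 percentage points lower from compound 1 to compound 2 (within the scatter), lies within the usual scatter, so the two numbers cannot be placed in order: compound 2 stands level with compound 1, and neither number can be called the higher of the pair.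

Compound 3, `CCCCCNC(=O)CC1CCc2cc(OC)c(OC)cc21`, is the next member of this series. It differs from compound 2 by methyl in place of hydrogen on a saturated chain carbon, four bonds along the chain from an amide-type nitrogen. Among the compounds with values here, the only measured step that speaks to this change is the one from compound 1 to compound 2, the same kind of change one bond nearer the nitrogen, and that step was a number 1.6 percentage points lower from compound 1 to compound 2 (within the scatter). On this evidence no move beyond the scatter is expected in this assay, in either direction. Compound 3 is therefore estimated to give 24%, with a range from 12% to 36%. That estimate means an expected step of a number 1 percentage points lower from compound 2 to compound 3 (within the scatter).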

Compound 3, a percentage reported as inhibition, in the whole organism at one dose (the size of the read-out at that dose, not a potency): 40.6%
For compound 3 the middle estimate is 16.6 percentage points below the measured one, and the stated range ends below it.
By their numbers in this assay, from the lowest: compounds 2 and 1 (each within the scatter of the next); then compound 3.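

In this assay, methyl in place of hydrogen four bonds along the chain from an amide-type nitrogen gives a number 15.6 percentage points higher from compound 2 to compound 3 (beyond the scatter), whereas the same kind of change three bonds along the chain stayed within the scatter, so adding one carbon to this chain does not have the same result at every position. Ethyl in place of hydrogen three bonds along the chain from an amide-type nitrogen gives a number 14 percentage points higher from compound 1 to compound 3 (beyond the scatter), which places the longest chain of the three clear of both shorter ones, and the two shorter chains go against any picture of a steady rise with each added carbon. Nothing measured alongside these numbers accounts for the jump at this position.

The compounds shown leave open whether a longer chain, such as hexyl or octyl, would carry the number further up, hold it level or bring it back down. They also leave open whether chain length alone matters here, or whether a branched chain of similar size, or an amine or a carboxylic acid at the far end of the chain, would give a different reading at this single dose.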